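This account rests on a few compounds, and the source may have more. Where it says the series, first, only, none or still open, it means among the compounds named here.

Three measured compounds share one core and differ only in the group attached to it. Compound 1 `Nc1cc(N)c2nc(-c3ccccc3)c(NCc3ccc(Cl)c(Cl)c3)nc2c1` carries a 3,4-dichlorobenzyl group joined through a nitrogen. In a functional assay on OVCAR-8 cells (Homo sapiens) for inhibition, read by sulforhodamine B assay, with a stated time of 48 h (a higher number here means a weaker inhibitor of growth, a lower number a stronger inhibitor of growth), compound 1 gives 3390 nM, the lowest number of the three and therefore the strongest growth inhibitor in this set. Compound 2 `Nc1cc(N)c2nc(-c3ccccc3)c(Oc3ccc(F)cc3)nc2c1`, with an aryl group joined through an oxygen, gives 22400 nM in this assay, a number well beyond the usual scatter above that of compound 1. Compound 3 `CCOC(=O)[C@H](CCC(=O)O)NC(=O)c1ccc(Oc2nc3cc(N)cc(N)c3nc2-c2ccccc2)cc1`, which carries a larger ester-bearing side chain, gives 38000 nM, the highest number and again clearly separated from compound 1.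

Compound 4 `COc1ccc(CNc2nc3cc(N)cc(N)c3nc2-c2ccccc2)cc1` has not been measured. It keeps the nitrogen-linked benzyl arrangement of compound 1 but changes the ring at its end: 4-methoxyphenyl in place of 3,4-dichlorophenyl on a saturated chain carbon bound to a nitrogen on an aromatic ring. Within the data shown here, no measured pair shows this exact change, so the expectation rests on the general spread seen among the three compounds. The step from compound 1 to compound 4 in this assay is expected to be modest and to run toward a higher number, that is toward weaker growth inhibition, as a 2.1-fold higher number from compound 1 to compound 4 (0.31 log units; beyond the scatter). Compound 4 is therefore estimated at 7000 nM, with a likely range from 2000 nM to 25000 nM.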

Compound 4, concentration for 50% growth inhibition: 14800 nM
The estimate for compound 4 lay 2.1-fold (0.33 log units) below the measured number, and the stated range covers the measured number.
By their numbers in this assay, from the lowest: compound 1; then compounds 4, 2 and 3 (each within the scatter of the next, the first and the last beyond it).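

Exchanging 3,4-dichlorobenzyl for 4-methoxybenzyl gives a 4.4-fold higher number from compound 1 to compound 4 (0.64 log units; beyond the scatter) in this assay, which means weaker growth inhibition. The earlier compounds shown here differed from one another in more than one feature, whereas this pair shares the nitrogen link and the saturated chain carbon, so it shows that the end ring alone can shift the number beyond the usual scatter. The two end groups have the same count of heavy atoms, although the entering 4-methoxyphenyl adds a hydrogen-bond acceptor and the chlorines are lost, and nothing measured here explains why the number moved.

This single step removes both chlorines and adds a methoxy group at once, so it cannot show how much each part of the exchange contributes. A 4-chlorophenyl group or an unsubstituted phenyl group at this place on a saturated chain carbon bound to a nitrogen on an aromatic ring could separate those parts, and a ring bearing an amine or a carboxylic acid would test quite different groups there.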